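Bromo in Place of Chloro on the Shared Core

The source may report more compounds than this note shows. Statements on the series, on what has been measured and on what is new or still open speak of the compounds shown alone.

Compound 3 `Oc1cc(C(F)(F)F)ccc1-c1nc(-c2ccccc2O)n(-c2ccc(Cl)cc2)n1` gives 87.3% in a functional assay on PC-12 cells (Rattus norvegicus) for cytotoxicity, read by MTT assay, with stated times of 2 h and 24 h, tested at 5 uM; on this read-out higher numbers stand for a stronger effect at the one concentration tested and lower numbers for a weaker effect. Compound 1 `CCc1ccc(-n2nc(-c3ccc(C(F)(F)F)cc3O)nc2-c2ccccc2O)cc1` gives 95.4% in this assay, and compound 2 `Oc1cc(C(F)(F)F)ccc1-c1nc(-c2ccccc2O)n(-c2ccc(F)cc2)n1` gives 86.7%; both steps to compound 3, a number 8.1 percentage points lower from compound 1 to compound 3 (within the scatter) and a number 0.6 percentage points higher from compound 2 to compound 3 (within the scatter), stay within the scatter, so the three numbers cannot be told apart. Compound 4 `Oc1cc(C(F)(F)F)ccc1-c1nc(-c2ccccc2O)n(-c2ccc(Br)cc2)n1` differs from compound 3 by bromo in place of chloro on an aromatic carbon. The step that bears on this change is the earlier halogen exchange on the same aromatic carbon, a number 0.6 percentage points higher from compound 2 to compound 3 (within the scatter), which stayed within the scatter, so no step beyond the scatter is expected in this assay. Compound 4 is therefore expected to give about 88%, between 78% and 97%, a step of a number 0.7 percentage points higher from compound 3 to compound 4 (within the scatter) that is expected to stay within the scatter.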

Compound 4, a percentage reported as activity, at one concentration (the size of the read-out at that concentration, not a potency): 89.8%
Beside the measured number, compound 4's estimate is 1.8 percentage points below it; the measured number falls inside the stated range.
By their numbers in this assay, from the lowest: compounds 2, 3, 4 and 1 (each within the scatter of the next).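

With bromo, this aromatic carbon, para to a large group, now carries fluoro, chloro, bromo and ethyl, and in this assay all three new steps stay within the scatter: a number 2.5 percentage points higher from compound 3 to compound 4 (within the scatter) and a number 3.1 percentage points higher from compound 2 to compound 4 (within the scatter) and a number 5.6 percentage points lower from compound 1 to compound 4 (within the scatter). The earlier compounds shown here showed this for fluoro, chloro and ethyl only; bromo now joins them as a fourth group that cannot be told apart from the rest. Nothing measured here offers an explanation for this result. The compounds shown leave open whether an amine, a carboxylic acid or a longer chain at this position would give a step beyond the scatter. They also leave open whether these four compounds would still be indistinguishable at a lower concentration.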